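The compounds below may be only part of what the source reports. "The series", "measured", "known", "first", "only" and "open" are said of these compounds alone.

Measured so far in a functional assay on the whole organism with Canis familiaris (Canis lupus familiaris) as the target; on this read-out higher numbers stand for an effect only at larger amounts of compound and lower numbers for an effect already at smaller amounts:
compound 1, `COC(=O)CC/C=C\CC[C@H]1C(=O)C[C@@H](O)[C@@H]1/C=C/C[C@@](C)(O)/C=C/C(C)=C(C)C`: compound 1 gives 0.00006 mg/kg
compound 2, `COC(=O)CC/C=C\CC[C@H]1C(=O)C[C@@H](O)[C@@H]1/C=C/C[C@@](C)(O)/C=C/C1=CCCC1`: compound 2 gives 0.00002 mg/kg

Among the measured compounds shown here, compound 2 stands lowest of the two numbers in this assay; its nearest neighbour is compound 1, and the single measured step between them, a 3.0-fold lower number from compound 1 to compound 2 (0.48 log units; beyond the scatter), came from a change of the open-chain group at the end of the side chain into the ring-bearing one.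

Compound 3, `C=C/C(C)=C/[C@](C)(O)C/C=C/[C@H]1[C@H](O)CC(=O)[C@@H]1CC/C=C\CCC(=O)OC`, is the next member. It differs from compound 2 as follows:
2-methylbuta-1,3-dien-1-yl in place of 2-(cyclopent-1-en-1-yl)ethenyl on a saturated chain carbon bound to an oxygen on a saturated carbon and two saturated chain carbons

For the measured compounds named here, the only step that bears on this change is the one from compound 1 to compound 2, where the ring entered and the number fell modestly. Compound 3 removes the ring again in favour of another open-chain group, though not the same one as in compound 1. A partial reversal of that earlier step is therefore expected: a modest rise in the number, a 2.5-fold higher number from compound 2 to compound 3 (0.40 log units; beyond the scatter), still beyond the scatter but not large. Compound 3 is estimated at 0.00005 mg/kg in this assay, with a range from 0.00001 mg/kg to 0.0002 mg/kg.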

Compound 3, dose for half-maximal effect: 0.00071 mg/kg
For compound 3 the middle estimate is 14-fold (1.15 log units) below the measured one; measured number above the stated range.
By their numbers in this assay, from the lowest: compound 2; then compound 1; then compound 3.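

In this assay the group on this saturated chain carbon matters far more than the first step suggested: the change to 2-methylbuta-1,3-dien-1-yl gives a large rise against both neighbours (a 36-fold higher number from compound 2 to compound 3 (1.55 log units; beyond the scatter); a 12-fold higher number from compound 1 to compound 3 (1.07 log units; beyond the scatter)). Loss of the ring cannot be the whole story, as compound 1 also has no ring in this group and still stands well below compound 3. No measurement at hand bears on the reason for this rise.

Still open, going by these compounds, is whether the number follows the ring, the carbon count of the group or the arrangement of its double bonds. A 2-phenylethenyl or 2-cyclopentylethenyl group on the same saturated chain carbon would help to separate these readings.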